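The source may hold more compounds than are shown below. What is called first, only, known or untested is meant among the compounds shown, and "the series" means these compounds.

Compound 1, `CS(=O)(=O)c1cncc(-c2ccc3ncc(-c4ccc(S(=O)(=O)C5CC5)cc4)n3n2)c1`: < 5000 nM (a limit of the assay, not a number)
Compound 2, `CS(=O)(=O)c1ccc(-c2cnc3ccc(-c4cccc(C(=O)N5CCC(O)CC5)c4)nn23)cc1`: > 200000 nM (a limit of the assay, not a number)
Compound 3, `CS(=O)(=O)c1cccc(-c2ccc3ncc(-c4ccc(S(=O)(=O)N5CCNCC5)cc4)n3n2)c1`: 166000 nM

All three were tested in a physicochemical assay for solubility, at pH 2; a lower number here means a less soluble compound, a higher number a more soluble compound. For compound 1 the assay reports only a limit (the limit of < 5000 nM in this assay, at which 1 of the 3 values shown sits). For compound 2 the assay likewise reports only a limit (the limit of > 200000 nM in this assay, at which 1 of the 3 values shown sits), so compound 2 sits at the soluble end of what this assay can report, and no exact number is known for it. Compound 3 is the only one of the three with a number, 166000 nM.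

Compound 4, `CS(=O)(=O)c1ccc(-c2cnc3ccc(-c4cccc(C(=O)NCCO)c4)nn23)cc1`, has not yet been measured. It differs from compound 2 in one place: (2-hydroxyethyl)amino in place of 4-hydroxypiperidin-1-yl on a carbonyl carbon. Among the compounds with values here, no pair of measured compounds shows the effect of such a change in this assay, so the size of the step cannot be read from the data. Compound 4 is expected to remain close to where compound 2 stands, with an expected step of a number no higher from compound 2 to compound 4 (the limit leaves the size open) of no more than the scatter, because compound 2 already gives > 200000 nM. The estimate for compound 4 is 200000 nM, in the range 80000 nM to 400000 nM.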

Compound 4, solubility: > 200000 nM
Compound 4: no number, only a limit (the forecaster's own chance of this, stated with the estimate: 50%); the middle value sits exactly at the limit.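

Within the data shown here, no step from compound 2 to compound 4 can be read in this assay: both results are limits of the assay, not numbers. Left open is whether (2-hydroxyethyl)amino in place of 4-hydroxypiperidin-1-yl on a carbonyl carbon changes the read-out at all, and by how much.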